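3,4-Dihydroxyphenyl in place of phenyl: notes on compound 4

This account rests on a few compounds, and the source may have more. Where it says the series, first, only, none or still open, it means among the compounds named here.

Measured in a functional assay for inhibition, with Homo sapiens as the target; on this read-out higher numbers stand for weaker inhibition and lower numbers for stronger inhibition:
compound 1 `O=C1CCc2cc(-c3csc(-c4cccnc4)n3)ccc2N1`: 1000 nM
compound 2 `O=C1CCc2cc(-c3csc(-c4ccccc4)n3)ccc2N1`: > 10000 nM (a limit)
compound 3 `CCCCOc1cc(-c2nc(-c3ccc4c(c3)CCC(=O)N4)cs2)ccc1OC`: 300 nM

Compound 2 gives only a limit, > 10000 nM, and no number. Its place in the series is the limit of > 10000 nM in this assay, at which 1 of the 3 values shown sits. Compound 4 `O=C1CCc2cc(-c3csc(-c4ccc(O)c(O)c4)n3)ccc2N1` differs from it by 3,4-dihydroxyphenyl in place of phenyl on an aromatic carbon.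

Within the data shown here, one measured step bears directly on this place: an at least 10-fold higher number from compound 1 to compound 2 (1.00 log units; beyond the scatter). Read in reverse, that step is the exchange of phenyl for another six-membered aromatic ring, and it leads from the limit to a number. Compound 3, which also lacks the plain phenyl, gives 300 nM. Neither compound carries the new group, so the transfer is uncertain. On the size of an at least 10-fold higher number from compound 1 to compound 2 (1.00 log units; beyond the scatter), a step of similar size towards a lower number is expected in this assay. The estimated step is an at least 6.6-fold lower number from compound 2 to compound 4 (0.82 log units; beyond the scatter). For compound 4 the expected value is 1500 nM, with an estimated range of 200 nM to 10000 nM.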

Compound 4, half-maximal inhibitory concentration: 1000 nM
Compound 4: the middle estimate sits 1.5-fold (0.18 log units) above what was measured; low and high end bracket the measured number.
By their numbers in this assay, from the lowest: compound 3; then compounds 1 and 4 (each within the scatter of the next). At a limit, above all of these: compound 2.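

At this aromatic carbon of the five-membered aromatic ring with 1 nitrogen and 1 sulfur, a ring of carbon only can give a measured value in this assay without a ring nitrogen, provided it carries the two hydroxyl groups of 3,4-dihydroxyphenyl: the result is an at least 10-fold lower number from compound 2 to compound 4 (1.00 log units; beyond the scatter). That step gives only a minimum size, since compound 2 stands at a limit: the limit of > 10000 nM in this assay, at which 1 of the 4 values shown sits. Pyridin-3-yl and 3,4-dihydroxyphenyl cannot be told apart in this read-out, with no change at the digits printed from compound 1 to compound 4 (within the scatter).

On these data alone, whether both hydroxyl groups are needed remains open, as a single hydroxyl on the phenyl would be the direct test. Also open, as far as these compounds go, is whether an amine or a carboxylic acid on that ring would serve in the same way.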